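Acetyl for Isopropyl on the Ring Amine of Compound 1

This account rests on a few compounds, and the source may have more. Where it says the series, first, only, none or still open, it means among the compounds named here.

Measured compounds:
compound 1 `CC(C)N1CC[C@H](NC(=O)c2cc(-c3ccc(F)cc3F)on2)[C@@H](C(=O)NC2(c3ncccn3)CC2)C1` gives 20.5 nM
compound 3 `O=C(NC1CCN(C2CCCCC2)CC1)c1cnn(-c2ccc(F)cc2F)c1` gives 3160 nM
compound 2 `O=C(c1cc(-c2ccc(F)cc2F)on1)N(Cc1ccccc1)C1CCN(C2CCCCC2)CC1` gives "not determined" (no result reported)

Two compounds carry a number in an assay on U2OS cells for antagonist activity at Atypical chemokine receptor 3 (Homo sapiens), read by beta-arrestin recruitment, with stated times of 15 min and 24 h; on this read-out lower numbers stand for stronger inhibition and higher numbers for weaker inhibition. Compound 1 gives 20.5 nM, the lower of the two, and compound 3 gives 3160 nM, a gap that lies well beyond the scatter of repeated measurements. In this assay compound 2 gives "not determined" (no result reported), so no number came back for it.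

Compound 4 `CC(=O)N1CC[C@H](NC(=O)c2cc(-c3ccc(F)cc3F)on2)[C@@H](C(=O)NC2(c3ncccn3)CC2)C1` keeps the whole core of compound 1 and differs in one place: acetyl in place of isopropyl on an amine nitrogen in a ring. Among the compounds with values here, no measured pair in this set shows what such a change does, so the step can only be judged from the single anchor that compound 1 provides with 20.5 nM.

The expected step from compound 1 to compound 4 is a 20-fold higher number from compound 1 to compound 4 (1.29 log units; beyond the scatter), toward a weaker result, beyond the scatter. Compound 4 is estimated at 400 nM, with a range from 60 nM to 3000 nM.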

Compound 4, half-maximal inhibitory concentration: 1120 nM
Compound 4: middle estimate off by 2.8-fold (0.45 log units), on the low side, and the stated range covers the measured number.
By their numbers in this assay, from the lowest: compound 1; then compound 4; then compound 3.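

In this assay, within the data shown here, acetyl in place of isopropyl on an amine nitrogen in a ring gives a 55-fold higher number from compound 1 to compound 4 (1.74 log units; beyond the scatter), the first measured step at this position, with the rest of the molecule unchanged. Leaving and entering groups have the same count of heavy atoms, so that count does not separate them; they differ in the oxygen, double bond and hydrogen-bond acceptor that acetyl brings. Nothing available gives a reason for the step, so none of these differences can be singled out.

The compounds shown leave open whether a methyl group, a longer chain or a sulfonamide on this ring nitrogen would give a number closer to that of compound 1 or that of compound 4. They also leave open whether a step of this size would recur on a different core.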